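Estimating compound 4 without a number for compound 3

The compounds below may be only part of what the source reports. "The series", "measured", "known", "first", "only" and "open" are said of these compounds alone.

compound 1 `CC(C)(C)c1cc2c(N/N=C/c3ccc(C(=O)O)cc3)ncnc2s1` - 7.22 ug/mL
compound 2 `CC(C)(C)c1cc2c(N/N=C/c3ccc(CN)cc3)ncnc2s1` - 0.214 ug/mL
compound 3 `COC(=O)c1ccc(/C=N/Nc2ncnc3sc(C(C)(C)C)cc23)cc1` - "not determined" (no result reported)

In a functional assay on PC-6 cells (Homo sapiens) for cytotoxicity, read by MTT assay, with a stated time of 3 days (on this read-out lower numbers stand for stronger inhibition and higher numbers for weaker inhibition), compound 3 has no place on the scale: its entry reads "not determined" (no result reported) and no single number exists for it. The move to compound 4 `CC(C)(C)c1cc2c(N/N=C/c3ccccc3)ncnc2s1` is the change hydrogen in place of methoxycarbonyl on an aromatic carbon in which hydrogen takes the place of methoxycarbonyl on an aromatic carbon. Within the data shown here, one measured step bears on this, also at an aromatic carbon: aminomethyl in place of carboxy gave a 34-fold lower number from compound 1 to compound 2 (1.53 log units; beyond the scatter) and that step is large, beyond the scatter. It shows that swapping one group can move the number far in this assay but it offers no measure for removing methoxycarbonyl. With no number for compound 3, no size or direction of step can be expected. The best remaining guide is the span of the measured compounds, with compound 1 at 7.22 ug/mL and compound 2 at 0.214 ug/mL as its ends. For compound 4 the estimated value is 1.5 ug/mL as a middle figure, with an expected range from 0.3 ug/mL to 8 ug/mL in this estimate.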

Compound 4, half-maximal inhibitory concentration: 6.54 ug/mL
Estimate against measurement, compound 4: 4.4-fold (0.64 log units) below, and the stated range covers the measured number.
By their numbers in this assay, from the lowest: compound 2; then compounds 4 and 1 (each within the scatter of the next).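

In this assay, hydrogen in place of aminomethyl on this aromatic carbon gives a 31-fold higher number from compound 2 to compound 4 (1.49 log units; beyond the scatter), a large step, while hydrogen in place of carboxy gives a 1.1-fold lower number from compound 1 to compound 4 (0.04 log units; within the scatter), which is within the scatter. Compound 4 therefore provides a reference with no group at this position: the carboxy compound cannot be told apart from it, and among these three compounds only the aminomethyl compound stands apart. Nothing available here explains why aminomethyl stands apart.

Steps to or from compound 3 cannot be read, so the effect of methoxycarbonyl at this position remains unknown. On these data alone, it is also open whether the large step belongs to aminomethyl alone or would extend to a longer chain such as aminoethyl, or to a dimethylaminomethyl group.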